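Methoxy in Place of Chloro: From Compound 2 to Compound 3

The compounds below may be only part of what the source reports. "The series", "measured", "known", "first", "only" and "open" are said of these compounds alone.

Within the data shown here, compound 2 `O=C1COCCN1c1ccc(Nc2nc(Cl)nc(Nc3ccc(Cl)cc3)n2)cc1` is one of two compounds measured in a functional assay on the whole organism (strain Swiss) for inhibition, with Mus musculus as the target, with a stated time of 30 min, at a dose of 5 mg/kg by the intraperitoneal route; on this read-out higher numbers stand for a stronger effect at the one dose given and lower numbers for a weaker effect. In this assay compound 2 gives 79%, and compound 1 `O=C1COCCN1c1ccc(Nc2nc(Cl)nc(N3CCCC3)n2)cc1` gives 87%; the two numbers lie within the scatter of each other, so neither can be called the stronger. Among the measured compounds shown here, the only measured step, a number 8 percentage points lower from compound 1 to compound 2 (within the scatter), came with (4-chlorophenyl)amino in place of pyrrolidin-1-yl on an aromatic carbon. Compound 3 `COc1ccc(Nc2nc(Cl)nc(Nc3ccc(N4CCOCC4=O)cc3)n2)cc1` differs from compound 2 in another way: methoxy in place of chloro on an aromatic carbon. For the measured compounds named here, no measured step of this kind, methoxy in place of chloro, exists, so the one known step offers no direct guide, and it was itself within the scatter. The expectation is therefore no change beyond the scatter, a step of a number 1 percentage points lower from compound 2 to compound 3 (within the scatter). Compound 3 is estimated at 78%, with a range from 60% to 92%.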

Compound 3, a percentage reported as inhibition, in the whole organism at one dose (the size of the read-out at that dose, not a potency): 47%
Compound 3: middle estimate off by 31 percentage points, on the high side; the whole stated range lies above it.
By their numbers in this assay, from the lowest: compound 3; then compounds 2 and 1 (each within the scatter of the next).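

In this assay, among these compounds, the only earlier step, a number 8 percentage points lower from compound 1 to compound 2 (within the scatter), lay within the scatter and gave no sign that the group at this end of the molecule mattered. The exchange of chloro for methoxy, on an aromatic carbon para to a large group, shows that it can: with the rest of the structure unchanged, the result is a number 32 percentage points lower from compound 2 to compound 3 (beyond the scatter). The (4-methoxyphenyl)amino group also separates from pyrrolidin-1-yl, with a number 40 percentage points lower from compound 1 to compound 3 (beyond the scatter), which (4-chlorophenyl)amino did not do beyond the scatter. Nothing available explains this drop.

The compounds shown leave open whether a fluoro, a methyl or a plain hydrogen at this place would stay with compound 2 or fall with compound 3. They also leave open whether a longer ether such as ethoxy would behave as methoxy does.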